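Lengthening the hydroxamate linker once more in the propargylamine series

The compounds below may be only part of what the source reports. "The series", "measured", "known", "first", "only" and "open" are said of these compounds alone.

Compound 1 `C#CCN(C)Cc1cccc(NC(=O)CCCCC(=O)NO)c1`: 5150 nM
Compound 2 `C#CCN(C)Cc1cccc(NC(=O)CCCCCC(=O)NO)c1`: 4630 nM
Compound 3 `C#CCN(C)Cc1cccc(NC(=O)CCCCCCC(=O)NO)c1`: 330 nM

In a functional assay on PC-3 cells (Homo sapiens) for inhibition, read by MTT assay, with a stated time of 48 h (on this read-out lower numbers stand for stronger inhibition of growth and higher numbers for weaker inhibition of growth), compound 3 gives the lowest number of the three, with steps of a 16-fold lower number from compound 1 to compound 3 (1.19 log units; beyond the scatter) and a 14-fold lower number from compound 2 to compound 3 (1.15 log units; beyond the scatter) separating it from the others, while a 1.1-fold lower number from compound 1 to compound 2 (0.05 log units; within the scatter) shows the two shorter-chain analogues are not distinguishable. Compound 4 `C#CCN(C)Cc1cccc(NC(=O)CCCCCCCCC(=O)NO)c1` differs from compound 3 by 2-(hydroxycarbamoyl)ethyl in place of hydroxycarbamoyl on a saturated chain carbon, six bonds along the chain from a carbonyl carbon. The two lengthening steps that reached compound 3 bear on this change, but both ran toward compound 3, and nothing measured shows what a further extension does. Compound 4 is therefore expected to give a number near that of compound 3 or somewhat higher, an estimated step of a 2.1-fold higher number from compound 3 to compound 4 (0.33 log units; beyond the scatter). Compound 4 is estimated at 700 nM, within 250 nM to 2500 nM.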

Compound 4, concentration for 50% growth inhibition: 1790 nM
Beside the measured number, compound 4's estimate is 2.6-fold (0.41 log units) below it; low and high end bracket the measured number.
By their numbers in this assay, from the lowest: compound 3; then compound 4; then compounds 2 and 1 (each within the scatter of the next).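

In this assay, lengthening the chain past compound 3 reverses the earlier gain, with a 5.4-fold higher number from compound 3 to compound 4 (0.73 log units; beyond the scatter), so growth inhibition does not keep improving as the chain grows. The longer chain still keeps part of the gain, with a 2.6-fold lower number from compound 2 to compound 4 (0.41 log units; beyond the scatter) and a 2.9-fold lower number from compound 1 to compound 4 (0.46 log units; beyond the scatter), so the four chain lengths show a turn at compound 3 rather than a steady trend. Nothing available explains this turn. Still open, from the compounds shown here alone, is how a chain of intermediate length, a still longer chain or a carboxylic acid in place of hydroxycarbamoyl would read.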